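Shortening the selenium chain from pentyl to methyl

A few compounds are considered here, and "the series" means these few. Any claim that something is new, unique, unknown or untested is made for them only; others in the source may bear on it.

Compound 1 `C[Se]c1nc([Se]C)c2cccnc2n1`: in a functional assay on HT-29 cells (Homo sapiens) for cytotoxicity, read by MTT assay, with a stated time of 72 h (a higher number here means that more compound is tolerated, a lower number that less compound is tolerated), compound 1 gives "not determined" (no result reported).
Compound 2 `Nc1nc([SeH])nc2ncccc12`: in this assay compound 2 gives > 100000 nM, which is a limit of the assay, not a number.
Compound 3 `CCCCC[Se]c1nc(N)c2cccnc2n1`: in this assay compound 3 gives 62100 nM.

Among the compounds with values here, compound 3 thus holds the only plain number here; the other entries are a limit and a missing result. Compound 4 `C[Se]c1nc(N)c2cccnc2n1` differs from compound 3 by hydrogen in place of butyl on a saturated chain carbon bound to a selenium atom. Within the data shown here, the one measured step that bears on this is an at least 1.6-fold lower number from compound 2 to compound 3 (0.20 log units; that floor lies within the scatter), and its floor lies within the scatter because it rests on (the limit of > 100000 nM in this assay, at which 1 of the 3 values shown sits). Moving part of the way back toward compound 2 is therefore expected to give no clear shift beyond the scatter, with a real chance of another limit. Compound 4 is expected to give 90000 nM, between 40000 nM and 200000 nM. The expected step is a 1.4-fold higher number from compound 3 to compound 4 (0.16 log units; within the scatter).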

Compound 4, concentration lethal to 50% of the cells: > 100000 nM
Compound 4 ended at the assay's limit; the forecaster's own chance of this, stated with the estimate: 45%; at least 1.1-fold (0.04 log units) between middle value and limit.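

In this assay, shortening pentyl to methyl on the selenium gives an at least 1.6-fold higher number from compound 3 to compound 4 (0.20 log units; that floor lies within the scatter), so even this large cut in the chain shows no readable step beyond the scatter. Within the data shown here, compound 2 and compound 4 both sit at a limit, so the step between them cannot be read, and compound 3 keeps the only plain number. The comparison at this position is capped by that ceiling: the limit of > 100000 nM in this assay, at which 2 of the 4 values shown sit. As far as these compounds go, whether a propyl chain on the selenium would give a plain number stays open. So does the effect of a longer chain, such as octyl, or of a chain ending in a carboxylic acid.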